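The source may report more compounds than this note shows. Statements on the series, on what has been measured and on what is new or still open speak of the compounds shown alone.

Measured compounds:
Compound 1 `N#CC1=C(N)Oc2c(c3nc4ccccc4nc3c3ccccc23)C12C(=O)N(Cc1cnnn1-c1ccc(Br)cc1)c1ccccc12` — in an ADME assay on HUVEC cells (Homo sapiens) for antiproliferative activity, read by MTT assay, with a stated time of 48 h (on this read-out higher numbers stand for weaker inhibition and lower numbers for stronger inhibition), compound 1 gives > 50000 nM, a limit of the assay and not a number.
Compound 2 `CCOc1ccccc1-n1nncc1CN1C(=O)C2(C(C#N)=C(N)Oc3c2c2nc4ccccc4nc2c2ccccc32)c2ccccc21` — in this assay compound 2 gives > 50000 nM, again a limit.
Compound 3 `N#CC1=C(N)Oc2c(c3nc4ccccc4nc3c3ccccc23)C12C(=O)N(Cc1cnnn1-c1ccc(N)cc1)c1ccccc12` — in this assay compound 3 gives > 50000 nM, again a limit.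

Compound 1 stands at the limit, and so do the two others: the limit of > 50000 nM in this assay, at which 3 of the 3 values shown sit. The three measured steps are therefore unreadable in size: a step that the two limits leave unreadable from compound 1 to compound 2; a step that the two limits leave unreadable from compound 1 to compound 3; a step that the two limits leave unreadable from compound 2 to compound 3. For the measured compounds named here, none of them gives a direction or a magnitude, only that every compound so far sits at the limit.

Compound 4 `N#CC1=C(N)Oc2c(c3nc4ccccc4nc3c3ccccc23)C12C(=O)N(Cc1cnnn1-c1ccc(S(N)(=O)=O)cc1)c1ccccc12` is not yet measured. It differs from compound 1 by sulfamoyl in place of bromo on an aromatic carbon. Going by the values given here, the steps that bear on it are the exchanges on the same aromatic nitrogen substituent in compound 1, compound 2 and compound 3, and all of them are unreadable, each value sitting at the limit. No step beyond the scatter is therefore expected in this assay, in either direction, and the most likely outcome for compound 4 is another limit.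

For compound 4 the estimate in this assay is 60000 nM, with a range from 25000 nM to 150000 nM. The expected step is a step that the limit leaves unreadable from compound 1 to compound 4, a formal number only, since compound 1 itself is known only as a limit.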

Compound 4, half-maximal inhibitory concentration: > 50000 nM
Compound 4: a limit, no number; the forecaster's own chance of this, stated with the estimate: 85%; the middle value lies beyond the limit too.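

Compound 4 adds no readable step: its steps from compound 1, compound 2 and compound 3 cannot be read in this assay, since each value is a limit and not a number: the limit of > 50000 nM in this assay, at which 4 of the 4 values shown sit.

Left open is how these four compounds rank against one another, and whether any change on the shared core gives a measurable value in this assay.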